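From Ether Side Chain to (Ethylcarbamoyl)amino: Expected Inhibition

The source may hold more compounds than are shown below. What is called first, only, known or untested is meant among the compounds shown, and "the series" means these compounds.

Measured so far in an assay on isolated protein (strain Sprague-Dawley) for inhibition of Amine oxidase [flavin-containing] A (Rattus norvegicus), read by spectrophotometry, with a stated time of 5 min, tested at 10 uM; on this read-out lower numbers stand for less inhibition and higher numbers for more inhibition at the one concentration tested (going by the name of the read-out):
Compound 1 `CC(C)Oc1cc(=O)oc2cc(OCc3cccc(Cl)c3)ccc12` gives 3%.
Compound 2 `COCOc1cc(=O)oc2cc(OCc3cccc(Cl)c3)ccc12` gives 23%.
Compound 3 `O=C(COc1cc(=O)oc2cc(OCc3cccc(Cl)c3)ccc12)N1CCCCC1` gives 9%.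

Compound 3 stands second highest of the three numbers. Its nearest neighbour is compound 1, with a number 6 percentage points higher from compound 1 to compound 3 (within the scatter), while compound 2 lies further off, with a number 14 percentage points lower from compound 2 to compound 3 (beyond the scatter). Compound 4 `CCNC(=O)Nc1cc(=O)oc2cc(OCc3cccc(Cl)c3)ccc12` differs from compound 3 in one place: (ethylcarbamoyl)amino in place of ((piperidin-1-yl)carbonyl)methoxy on an aromatic carbon. Within the data shown here, none of the measured steps bears directly on this change. The two steps that exist, a number 20 percentage points higher from compound 1 to compound 2 (beyond the scatter) and a number 14 percentage points lower from compound 2 to compound 3 (beyond the scatter), alter only the chain on the oxygen on the aromatic ring and move the numbers modestly at most, and all three compounds stay low. Compound 4 is therefore expected to stay near the measured range, with a step of a number 1 percentage points higher from compound 3 to compound 4 (within the scatter), not beyond the scatter. The estimate for compound 4 is 10%, within 0% to 30%.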

Compound 4, a percentage reported as inhibition, at one concentration (the size of the read-out at that concentration, not a potency): 0%
Estimate against measurement, compound 4: 10 percentage points above, within the range that was stated.
By their numbers in this assay, from the lowest: compounds 4, 1 and 3 (each within the scatter of the next); then compound 2.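

In this assay, among these compounds, the step of a number 23 percentage points lower from compound 2 to compound 4 (beyond the scatter) shows that (ethylcarbamoyl)amino, the first group here attached through nitrogen rather than oxygen, does not keep the number seen with methoxymethoxy on this aromatic carbon. The steps of a number 9 percentage points lower from compound 3 to compound 4 (within the scatter) and a number 3 percentage points lower from compound 1 to compound 4 (within the scatter) separate it from neither ((piperidin-1-yl)carbonyl)methoxy nor isopropoxy, so methoxymethoxy alone stands apart among these groups. No measurement shown accounts for these differences.

The compounds shown leave open how a plain amine or a carboxylic acid on this aromatic carbon would read. They also leave open whether a longer chain in place of the ethyl group would change the number.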